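The source may hold more compounds than are shown below. What is called first, only, known or untested is meant among the compounds shown, and "the series" means these compounds.

In a functional assay on the whole organism for inhibition, with Mus musculus as the target, with stated times of 30 min and 2 h, at a dose of 10 mg/kg by the intraperitoneal route (a higher number here means more inhibition at the dose given (going by the name of the read-out), a lower number less inhibition), compound 1 `O=C(NCc1ccc(CNS(=O)(=O)c2ccccc2)cc1)c1cccnc1` gives 53%, and compound 2 `Cc1ccc(S(=O)(=O)NCc2ccc(CNC(=O)c3ccccc3Cl)cc2)cc1` gives 26%. Compound 3 `Cc1ccccc1C(=O)NCc1ccc(CNS(=O)(=O)c2ccccc2)cc1` is reported in this assay as "not active" (no number reported), with no number attached, so it cannot be placed on the same scale as the other two. Compound 4 `O=C(NCc1ccc(CNS(=O)(=O)c2ccccc2)cc1)c1ccccc1Cl` differs from compound 3 by chloro in place of methyl on an aromatic carbon. For the measured compounds named here, no measured pair shows what this single change does on its own, so its size and direction remain open. Compound 4 carries the same (2-chlorophenyl)carbonyl group as compound 2, which gives 26%, while compound 3 has no number at all. Compound 4 is expected to give about 20%, with a likely range from 0% to 45%.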

Compound 4, a percentage reported as inhibition, in the whole organism at one dose (the size of the read-out at that dose, not a potency): "not active" (no number reported)
Compound 4: no number reported, so the estimate cannot be set against anything.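

For the compounds shown here, compound 3 and compound 4 are both reported as not active, without a number, in this assay, so no step between them can be read. No evidence here accounts for this result. On these data alone, what replacing methyl with chloro does on its own remains open.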